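From Propyl to Isopropyl: Predicting Compound 3

This account rests on a few compounds, and the source may have more. Where it says the series, first, only, none or still open, it means among the compounds named here.

Of the compounds shown here, two sharing one core have so far been measured in a functional assay on the whole organism with Rattus norvegicus as the target, at a dose of 1 mg/kg by the oral route; on this read-out higher numbers stand for a stronger effect at the one dose given and lower numbers for a weaker effect. Compound 1 `COc1cc(C(=O)Nc2nn[nH]n2)nc(-c2ccccc2)c1` carries hydrogen on the aromatic carbon in question, and in this assay compound 1 gives 62%. Compound 2 `CCCc1ccc(-c2cc(OC)cc(C(=O)Nc3nn[nH]n3)n2)cc1` carries propyl at that place, and in this assay compound 2 gives 73%. Among the measured compounds shown here, the only step measured, a number 11 percentage points higher from compound 1 to compound 2 (beyond the scatter), leaves compound 2 standing highest of the two numbers, with compound 1 as its nearest neighbour, a step beyond the scatter.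

Compound 3 `COc1cc(C(=O)Nc2nn[nH]n2)nc(-c2ccc(C(C)C)cc2)c1` has not yet been measured. It differs from compound 2 in one place: isopropyl in place of propyl on an aromatic carbon. For the measured compounds named here, the single measured step bears on this only loosely: it shows that the change from hydrogen to propyl on this aromatic carbon gave a modest rise, but nothing measured shows how a branched chain compares with a straight one of the same atoms. The two compounds have the same atoms, joined differently, and the expected step of a number 3 percentage points lower from compound 2 to compound 3 (within the scatter) is none beyond the scatter. Compound 3 is therefore estimated at 70%, with a range from 55% to 85%.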

Compound 3, a percentage reported as inhibition, in the whole organism at one dose (the size of the read-out at that dose, not a potency): 54%
For compound 3 the middle estimate is 16 percentage points above the measured one, and the stated range ends above it.
By their numbers in this assay, from the lowest: compounds 3 and 1 (each within the scatter of the next); then compound 2.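

In this assay the way the same carbon atoms are joined at this place turns out to matter, something the earlier pair could not show: swapping propyl for isopropyl gives a number 19 percentage points lower from compound 2 to compound 3 (beyond the scatter) even though neither group gains or loses an atom. The branched chain also fails to keep the rise seen with the straight one, since the comparison with hydrogen reads a number 8 percentage points lower from compound 1 to compound 3 (within the scatter) and so does not separate compound 3 from compound 1; among these three compounds, only propyl stands apart from hydrogen at this position. Nothing measured here accounts for the gap between the two chains.

The compounds shown leave open whether a longer straight chain such as butyl would hold or extend the value of propyl, or whether a more branched group such as tert-butyl would fall with isopropyl. They also leave open how a group of another kind, such as an amine or a carboxylic acid, would behave on this aromatic carbon, para to a large group.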